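A few compounds are considered here, and "the series" means these few. Any claim that something is new, unique, unknown or untested is made for them only; others in the source may bear on it.

Working notes on the series. Compound 1 `COc1cccc(/C=C/C(=O)c2sc(Nc3cccc(C)c3)nc2C)c1`, compound 2 `COc1cccc(/C=C/C(=O)c2sc(Nc3ccccc3C)nc2C)c1` and compound 3 `COc1cc(/C=C/C(=O)c2sc(Nc3ccccc3C)nc2C)cc(OC)c1OC` have each been tested in a functional assay on PC-3 cells (Homo sapiens) for cytotoxicity, read by MTT assay; on this read-out higher numbers stand for weaker inhibition and lower numbers for stronger inhibition. In this assay compound 1 returns only a limit of the assay, > 25000 nM. In this assay compound 2 likewise returns a limit, > 25000 nM. In this assay compound 3 also returns a limit, > 25000 nM. How the core of compound 3 differs from that of compound 2 is not broken down here. From compound 2 to compound 1 the change is 3-methylphenyl in place of 2-methylphenyl on a nitrogen on an aromatic ring, and the step that the two limits leave unreadable from compound 2 to compound 1 stays unreadable because of the limit of > 25000 nM in this assay, at which 3 of the 3 values shown sit.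

Compound 4 `COc1cc(/C=C/C(=O)c2sc(Nc3cccc(C)c3)nc2C)cc(OC)c1OC` is still to be measured. It differs from compound 3 by the same change, (3-methylphenyl in place of 2-methylphenyl on a nitrogen on an aromatic ring), at the same place. For the measured compounds named here, since the one measured instance of this change gives no readable size, the expectation for compound 4 rests only on (the limit of > 25000 nM in this assay, at which 3 of the 3 values shown sit), where compound 3 stands. The step from compound 3 to compound 4 is therefore expected to be a step that the limit leaves unreadable from compound 3 to compound 4, most likely again beyond what the assay resolves. Compound 4 is estimated at 30000 nM, between 10000 nM and 100000 nM.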

Compound 4, half-maximal inhibitory concentration: > 25000 nM
Compound 4: a limit, no number; the forecaster's own chance of this, stated with the estimate: 85%; the middle value lies beyond the limit too.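

No step can be read between compound 3 and compound 4, because both return only a limit of the assay in this assay: the limit of > 25000 nM in this assay, at which 4 of the 4 values shown sit.

The compounds shown leave open how far each lies past that limit, and whether 3-methylphenyl in place of 2-methylphenyl has any effect on the read-out.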